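Cyclopropyl for the silicon group on the triazole ring

This account rests on a few compounds, and the source may have more. Where it says the series, first, only, none or still open, it means among the compounds named here.

Two compounds of the series carry a number in an ADME assay on HFF cells (Homo sapiens) for cytotoxicity, read by MTT assay, with a stated time of 72 h; on this read-out higher numbers stand for weaker inhibition and lower numbers for stronger inhibition. Compound 1 `C[Si](C)(C)c1cn(C[C@H](O)[C@H]2OC(=O)C(OCc3ccccc3)=C2OCc2ccccc2)nn1` gives 20000 nM in this assay, the higher of the two numbers. Compound 2 `CC(C)(C)OC(=O)N1CCN(C(=S)SCc2cn(C[C@H](O)[C@H]3OC(=O)C(OCc4ccccc4)=C3OCc3ccccc3)nn2)CC1` gives 60 nM in this assay, a lower number and beyond the scatter from compound 1, so compound 1 is the weaker inhibitor of the pair. Within the data shown here, no step between compounds that differ in one place is available, so the size of a single change remains to be learned.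

Compound 3 `O=C1O[C@H]([C@@H](O)Cn2cc(C3CC3)nn2)C(OCc2ccccc2)=C1OCc1ccccc1` is not yet measured in this assay. It differs from compound 1 by a group of 3 heavy atoms (3 carbon; one three-membered non-aromatic ring of carbon only) in place of a group of 4 heavy atoms (3 carbon, 1 silicon; no ring), on an aromatic carbon, on the aromatic carbon of the five-membered aromatic ring with 3 nitrogen. Cyclopropyl in place of a group of 4 heavy atoms (3 carbon, 1 silicon; no ring) is expected to move the number little; the step of a 1.3-fold lower number from compound 1 to compound 3 (0.12 log units; within the scatter) is estimated to stay within or close to the scatter. Compound 3 is expected to give about 15000 nM in this assay, between 5000 nM and 40000 nM.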

Compound 3, half-maximal inhibitory concentration: 24300 nM
Compound 3: middle estimate off by 1.6-fold (0.21 log units), on the low side; measured number inside the range.
By their numbers in this assay, from the lowest: compound 2; then compounds 1 and 3 (each within the scatter of the next).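

In this assay, among these compounds, cyclopropyl in place of the group of 4 heavy atoms (3 carbon, 1 silicon) on the aromatic carbon of the five-membered aromatic ring with 3 nitrogen gives a 1.2-fold higher number from compound 1 to compound 3 (0.08 log units; within the scatter), the first single-place step. At this position, then, silicon is not required for a number of this size, since a group of carbon only reads the same within the scatter. Nothing measured here speaks to the reason for this.

Still open, going by these compounds, is whether a small group of another kind at this position, such as an amine or a carboxylic acid, would also leave the number in place. Also open, on these data alone, is which part of the large group on compound 2 goes with its 60 nM, for instance the piperazine ring or the tert-butyl carbamate.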